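Swapping methoxy for chloro on an ester ring

The source may hold more compounds than are shown below. What is called first, only, known or untested is meant among the compounds shown, and "the series" means these compounds.

Of the compounds shown here, three sharing one core have been measured in an assay on NIH3T3 cells with Urotensin-2 receptor (Homo sapiens) as the target; on this read-out lower numbers stand for smaller maximal responses and higher numbers for larger maximal responses. Compound 1 `Cc1ccsc1C(=O)OC(CCN(C)C)c1ccc(Cl)cc1` gives 119%, compound 2 `CCc1ccccc1C(=O)OC(CCN(C)C)c1ccc(Cl)cc1` gives 128%, and compound 3 `COc1cccc(C(=O)OC(CCN(C)C)c2ccc(Cl)cc2)c1C` gives 88%. Compound 3 thus stands lowest of the three, with a gap to compound 1 and to compound 2 that lies beyond the scatter. Among the compounds with values here, the one step between measured compounds, a number 9 percentage points higher from compound 1 to compound 2 (within the scatter), replaces one aromatic group on the carbonyl carbon with another and stays within the scatter.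

Compound 4 `Cc1c(Cl)cccc1C(=O)OC(CCN(C)C)c1ccc(Cl)cc1` is obtained from compound 3 by a single change: chloro in place of methoxy on an aromatic carbon. Within the data shown here, no measured step exchanges a methoxy for a chloro, so the only guide is the small effect seen when the whole aromatic group was swapped in the step from compound 1 to compound 2. On that basis the expected step is modest and of uncertain direction, a number 12 percentage points higher from compound 3 to compound 4 (beyond the scatter). Compound 4 is therefore estimated at 100%, with a range from 72% to 128%.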

Compound 4, largest response reached (reported as efficacy), in percent of the reference or control that the assay uses: 118%
For compound 4 the middle estimate is 18 percentage points below the measured one, within the range that was stated.
By their numbers in this assay, from the lowest: compound 3; then compounds 4, 1 and 2 (each within the scatter of the next).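

In this assay chloro in place of methoxy on this aromatic carbon, ortho to a methyl group, gives a number 30 percentage points higher from compound 3 to compound 4 (beyond the scatter) and so shows that a change at this one position can alter the maximal response. Exchanging the whole aromatic group on the carbonyl carbon gives a number 10 percentage points lower from compound 2 to compound 4 (within the scatter) and a number 1 percentage points lower from compound 1 to compound 4 (within the scatter) and sets compound 4 level with both earlier compounds, which leaves compound 3 alone at the low end of the four. Nothing measured here explains why methoxy and chloro differ at this position.

Still open, as far as these compounds go, is whether the lower response belongs to methoxy alone or would also appear with fluoro, a hydroxyl or an amine on this carbon. Also open, from the compounds shown here alone, is whether a longer chain such as ethoxy would lower the response further.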